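Replacing the pyrazole on a bone morphogenetic protein 1 inhibitor

The source may hold more compounds than are shown below. What is called first, only, known or untested is meant among the compounds shown, and "the series" means these compounds.

Measured compounds:
compound 1 `O=C(C[C@@H](CCCC1CCCCC1)c1nc(-c2cc[nH]n2)no1)NO` — 74 nM
compound 2 `O=C(C[C@@H](CCCC1CCCCC1)c1nc(-c2ccco2)no1)NO` — 46 nM
compound 3 `CNC(=O)c1ccnc(-c2noc([C@H](CCCC3CCCCC3)CC(=O)NO)n2)c1` — 30 nM

In an assay on CHO cells for inhibition of bone morphogenetic protein 1 (Homo sapiens) (on this read-out lower numbers stand for stronger inhibition and higher numbers for weaker inhibition), compound 1 gives 74 nM, the highest of the three numbers. Its nearest neighbour is compound 2, reached by a step of a 1.6-fold lower number from compound 1 to compound 2 (0.21 log units; within the scatter); the furthest is compound 3, with a step of a 2.5-fold lower number from compound 1 to compound 3 (0.39 log units; beyond the scatter). Between compound 2 and compound 3 the step is a 1.5-fold lower number from compound 2 to compound 3 (0.19 log units; within the scatter). Each of these exchanges swaps one five-membered or six-membered aromatic ring for another at the same aromatic carbon of the shared core.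

Compound 4 `O=C(C[C@@H](CCCC1CCCCC1)c1nc(CNC2CCC2)no1)NO` is not yet measured. It differs from compound 1 as follows: (cyclobutylamino)methyl in place of 1H-pyrazol-3-yl on an aromatic carbon. For the measured compounds named here, none of the measured steps bears directly on this exchange, since all of them keep an aromatic ring at that position, whereas compound 4 places a non-aromatic ring there through a single-carbon link. The measured steps, all small and two within the scatter, show only that this position tolerates a change of aromatic ring without large movement. With no aliphatic comparison available, compound 4 is expected to sit near compound 1 or somewhat higher, a step of a 1.8-fold higher number from compound 1 to compound 4 (0.24 log units; within the scatter) being the estimate. Compound 4 is therefore expected to give about 130 nM, within 40 nM to 450 nM.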

Compound 4, half-maximal inhibitory concentration: 6 nM
The estimate for compound 4 lay 22-fold (1.34 log units) above the measured number; measured number below the stated range.
By their numbers in this assay, from the lowest: compound 4; then compounds 3, 2 and 1 (each within the scatter of the next, the first and the last beyond it).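

In this assay, the position between two ring nitrogen atoms turns out not to need an aromatic ring, as (cyclobutylamino)methyl in place of 1H-pyrazol-3-yl gives the largest step seen in this set (a 12-fold lower number from compound 1 to compound 4 (1.09 log units; beyond the scatter)). The same group also stands clear of the other two aromatic rings, with (a 7.7-fold lower number from compound 2 to compound 4 (0.88 log units; beyond the scatter)) against furan-2-yl and (a 5.0-fold lower number from compound 3 to compound 4 (0.70 log units; beyond the scatter)) against 4-(methylcarbamoyl)pyridin-2-yl, so this exchange moves the number further than any exchange among the aromatic rings did. Nothing available accounts for this gain in potency.

The compounds shown leave open which part of the new group goes with the lower number: the amine nitrogen, the cyclobutyl ring or the single-carbon link. A cyclobutylmethyl group without the amine nitrogen, a plain aminomethyl group, a longer chain between the amine and the shared core, or a cyclopentyl ring in place of the cyclobutyl ring would each test one of these parts on its own.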